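Methylating a hydroxy group of compound 1

The source may hold more compounds than are shown below. What is called first, only, known or untested is meant among the compounds shown, and "the series" means these compounds.

compound 1 `Oc1ccc(/C=C/c2cccc(O)c2)cc1` gives 6.9 ug/mL
compound 2 `Nc1ccc(/C=C/c2cccc(O)c2)cc1` gives 42 ug/mL
compound 3 `COc1cccc(/C=C/c2ccc(O)cc2)c1` is not yet measured

These numbers come from a functional assay on HT-29 cells (Homo sapiens) for inhibition, read by MTT assay, with a stated time of 2 days (on this read-out lower numbers stand for stronger inhibition and higher numbers for weaker inhibition), and compound 1 holds the lower of the two. Compound 3 differs from compound 1 by methyl in place of hydrogen on an oxygen on an aromatic ring in the change of hydroxy to methoxy. Among the compounds with values here, no measured step makes this exact change. Within the data shown here, the only guide is the step with amino in place of hydroxy on an aromatic carbon, which is a 6.1-fold higher number from compound 1 to compound 2 (0.78 log units; beyond the scatter) and alters the other hydroxy of compound 1. It is a modest step and only loosely related. A smaller step towards a higher number is therefore expected in this assay and it may not exceed the scatter. The estimated step is a 1.7-fold higher number from compound 1 to compound 3 (0.24 log units; within the scatter) for this change. For compound 3 the estimate is 12 ug/mL with an expected range from 4 ug/mL to 40 ug/mL in this assay.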

Compound 3, half-maximal inhibitory concentration: 26 ug/mL
Beside the measured number, compound 3's estimate is 2.2-fold (0.34 log units) below it, within the range that was stated.
By their numbers in this assay, from the lowest: compound 1; then compounds 3 and 2 (each within the scatter of the next).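

In this assay, within the data shown here, putting a methyl on this hydroxy oxygen gives a 3.8-fold higher number from compound 1 to compound 3 (0.58 log units; beyond the scatter), the first measured evidence that this hydroxy cannot be capped without a real loss of inhibition. The earlier step, a 6.1-fold higher number from compound 1 to compound 2 (0.78 log units; beyond the scatter), changed only the other hydroxy, so each of the two hydroxy groups has now been altered once, and both single changes moved the number upward beyond the scatter. Nothing available explains why methyl on this oxygen weakens inhibition.

The shown compounds cover only one replacement at each hydroxy, and the methoxy change has been seen at just this one of the two. On these data alone, whether a longer ethoxy chain or an amino group in place of this hydroxy would give a similar number remains open, as does the effect of methoxy at the other hydroxy.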